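A few compounds are considered here, and "the series" means these few. Any claim that something is new, unique, unknown or untested is made for them only; others in the source may bear on it.

Among the compounds with values here, compound 1 `O=S(=O)(/C=C/c1ccc(O)c(O)c1)CC1CCCN1` gives 13800 nM in a functional assay, read by fluorescence and spectrophotometry, with a stated time of 1 h (a lower number here means that less compound is needed, a higher number that more compound is needed for the effect), the highest of the three numbers known. Compound 2 `CCCCCCCCCS(=O)(=O)/C=C/c1ccc(O)c(O)c1` gives 7700 nM, and compound 3 `CC(C)(C)OC(=O)N1CCCC1CS(=O)(=O)/C=C/c1ccc(O)c(O)c1` gives 7100 nM, both within the scatter of compound 1; the step of a 1.9-fold lower number from compound 1 to compound 3 (0.29 log units; within the scatter) stays within the scatter. Compound 4 `O=S(=O)(/C=C/c1ccc(O)c(O)c1)CC1CC1` differs from compound 1 as follows: cyclopropyl in place of pyrrolidin-2-yl on a saturated chain carbon bound to a sulfonyl sulfur. Within the data shown here, the one measured step that bears on this, the one from compound 1 to compound 3, also altered the amine nitrogen in a ring, by tert-butoxycarbonyl in place of hydrogen, and did not move the number beyond the scatter. The expected step of a 1.5-fold lower number from compound 1 to compound 4 (0.19 log units; within the scatter) is therefore estimated to lie within the scatter. Compound 4 is estimated in this assay at 9000 nM, between 3500 nM and 25000 nM.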

Compound 4, half-maximal effective concentration: 10500 nM
The estimate for compound 4 lay 1.2-fold (0.07 log units) below the measured number; measured number inside the range.
By their numbers in this assay, from the lowest: compounds 3, 2, 4 and 1 (each within the scatter of the next).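

In this assay the exchange of pyrrolidin-2-yl for cyclopropyl gives a 1.3-fold lower number from compound 1 to compound 4 (0.12 log units; within the scatter) and so does not move the number beyond the scatter. Compound 3 kept the ring nitrogen under a tert-butoxycarbonyl group, whereas compound 4 has no nitrogen in this group, and its number still stays within the scatter of compound 1. Nothing measured here explains this result. From the compounds shown here alone, whether a carboxylic acid or a longer chain on this saturated chain carbon would move the number beyond the scatter remains open.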